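Longer Alkyl Chains on a Shared Core: Expected Cytotoxicity

This account rests on a few compounds, and the source may have more. Where it says the series, first, only, none or still open, it means among the compounds named here.

In a functional assay on HEL cells (Homo sapiens) (a lower number here means that less compound is tolerated, a higher number that more compound is tolerated), compound 1 `CCCCCCCCc1cc2cn(C3CCC(CO)O3)c(=O)nc2o1` gives only the limit > 112000 nM. Compound 2 `CCCCCCCCCCCc1cc2cn(C3CCC(CO)O3)c(=O)nc2o1` gives only the limit > 200000 nM. Compound 3 `CCCCCCCCCCCCc1cc2cn(C3CCC(CO)O3)c(=O)nc2o1` gives only the limit > 200000 nM.

Compound 1 thus stands at a limit rather than a number, as do the two other compounds. Compound 4 `CCCCCCCCCCCCCCc1cc2cn(C3CCC(CO)O3)c(=O)nc2o1` differs from compound 1 by hexyl in place of hydrogen on a saturated chain carbon, eight bonds along the chain from an aromatic carbon. The comparable steps, a step that the two limits leave unreadable from compound 1 to compound 2, a step that the two limits leave unreadable from compound 1 to compound 3 and a step that the two limits leave unreadable from compound 2 to compound 3, are all unreadable, since every value sits at a limit: the limit of > 112000 nM in this assay, at which 1 of the 3 values shown sits, and (the limit of > 200000 nM in this assay, at which 2 of the 3 values shown sit). Nothing beyond the scatter is therefore readable, and compound 4 is expected to remain at a limit as well. Compound 4 is estimated at 200000 nM, with a range from 100000 nM to 400000 nM. The expected step is a step that the limit leaves unreadable from compound 1 to compound 4.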

Compound 4, half-maximal cytotoxic concentration: > 200000 nM
Compound 4: a limit, no number; the forecaster's own chance of this, stated with the estimate: 85%; the middle value lies on the limit itself.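

Among the compounds shown here, compound 4, like compound 1, compound 2 and compound 3, gives only a limit in this assay, and no step between these compounds can be read. The compounds shown leave open the actual cytotoxic concentration of each, and whether chain length alters it.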